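Swapping chloro for trifluoromethyl on the shared core

The source may report more compounds than this note shows. Statements on the series, on what has been measured and on what is new or still open speak of the compounds shown alone.

Three compounds sharing one core, each carrying a cyclopropylmethyl group and a chloro substituent, have been tested in a functional assay on CHO cells for agonist activity at metabotropic glutamate receptor 2 (Homo sapiens), read by scintillation counting and GTPgammaS binding, with a stated time of 30 min; a lower number here means that less compound is needed, a higher number that more compound is needed for the effect. Compound 1 `COc1ccc(F)cc1C1CCN(c2ccn3c(CC4CC4)nnc3c2Cl)CC1` gives 8.2 nM, compound 2 `COc1c(F)ccc(F)c1C1CCN(c2ccn3c(CC4CC4)nnc3c2Cl)CC1` gives 7.5 nM, and compound 3 `COc1ccc(F)c(F)c1C1CCN(c2ccn3c(CC4CC4)nnc3c2Cl)CC1` gives 9.3 nM. Compound 2 holds the lowest of the three numbers, but its neighbours sit close: a 1.1-fold lower number from compound 1 to compound 2 (0.04 log units; within the scatter) and a 1.2-fold higher number from compound 2 to compound 3 (0.09 log units; within the scatter), while a 1.1-fold higher number from compound 1 to compound 3 (0.05 log units; within the scatter). All three steps concern fluorine on the pendant phenyl ring and none reaches beyond the scatter.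

Compound 4 `COc1c(F)ccc(F)c1C1CCN(c2ccn3c(CC4CC4)nnc3c2C(F)(F)F)CC1` differs from compound 2 at another place: trifluoromethyl in place of chloro on an aromatic carbon. Among the measured compounds shown here, none of the measured steps touches this position, so the measured data give no direct guide to the size or direction of this change. Absent such a guide, the step of a 1.3-fold higher number from compound 2 to compound 4 (0.12 log units; within the scatter) is expected to stay modest, though with wider uncertainty than the phenyl steps. Compound 4 is therefore estimated to give about 10 nM in this assay, within a range from 3 nM to 40 nM.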

Compound 4, half-maximal effective concentration: 4.1 nM
Beside the measured number, compound 4's estimate is 2.4-fold (0.39 log units) above it, and the stated range covers the measured number.
By their numbers in this assay, from the lowest: compounds 4, 2, 1 and 3 (each within the scatter of the next, the first and the last beyond it).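

The step at this position, on an aromatic carbon ortho to a fused ring, is the only one shown to touch anything other than the pendant phenyl ring. In this assay it gives a 1.8-fold lower number from compound 2 to compound 4 (0.26 log units; within the scatter) and so does not separate trifluoromethyl from chloro, even though the entering group has four heavy atoms and the leaving group one. The position therefore accepts the larger of these two groups in compound 4 without a change that can be told from the scatter, and nothing given here offers an explanation for this result.

The compounds shown leave open whether the same swap would read alike with the phenyl patterns of compound 1 and compound 3. They also leave open how a nitrile, an amine or a plain hydrogen would fare at this position.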